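Aryl variation at the hydrazone carbon

This account rests on a few compounds, and the source may have more. Where it says the series, first, only, none or still open, it means among the compounds named here.

Compound 1 `COc1ccc(/C=N\NC(=S)NC(C)(C)CCC[C@](C)(O)[C@@H]2CC=C(C)CC2)cc1` gives 76100 nM in a functional assay on PCO3 cells (Homo sapiens) for cytotoxicity, read by sulforhodamine B assay; on this read-out higher numbers stand for weaker inhibition of growth and lower numbers for stronger inhibition of growth.
Compound 2 `CC1=CC[C@@H]([C@@](C)(O)CCCC(C)(C)NC(=S)N/N=C\c2ccc(O)cc2)CC1` gives 13900 nM in this assay.
Compound 3 `CC1=CC[C@@H]([C@@](C)(O)CCCC(C)(C)NC(=S)N/N=C\c2ccc(N(C)C)cc2)CC1` reaches only the assay limit > 100000 nM in this assay.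

Compound 3 is known only as a floor: it sits at the limit of > 100000 nM in this assay, at which 1 of the 3 values shown sits, so the step of an at least 7.1-fold higher number from compound 2 to compound 3 (0.85 log units; beyond the scatter) is a minimum, while the step of an at least 1.3-fold higher number from compound 1 to compound 3 (0.11 log units; that floor lies within the scatter) does not separate it from compound 1. Compound 4 `CC1=CC[C@@H]([C@@](C)(O)CCCC(C)(C)NC(=S)N/N=C\c2ccccc2[N+](=O)[O-])CC1` carries 2-nitrophenyl in place of 4-(dimethylamino)phenyl on a carbon with a double bond to nitrogen. Going by the values given here, none of the measured steps covers a nitrophenyl group; the three measured compounds show only that changing the aryl substituent moves the number from compound 2 up to the limit of compound 3, with a 5.5-fold lower number from compound 1 to compound 2 (0.74 log units; beyond the scatter) the largest quantified movement. Compound 4 in this assay is therefore expected to land inside that span, estimated at 50000 nM with a range from 10000 nM to 150000 nM. For compound 4 this means an expected step of an at least 2.0-fold lower number from compound 3 to compound 4 (0.30 log units; that floor lies within the scatter), with a real chance that only a limit is again reported.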

Compound 4, concentration for total growth inhibition: > 100000 nM
Compound 4: a limit, no number; the forecaster's own chance of this, stated with the estimate: 30%; middle value at least 2.0-fold (0.30 log units) away from the limit.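

In this assay compound 4 gives a limit, not a number, so a second aryl group now sits at the top of the range: the limit of > 100000 nM in this assay, at which 2 of the 4 values shown sit. 2-Nitrophenyl in place of 4-hydroxyphenyl gives an at least 7.1-fold higher number from compound 2 to compound 4 (0.85 log units; beyond the scatter), which shows that a nitro-bearing aryl group also loses the reading of compound 2, while 2-nitrophenyl in place of 4-methoxyphenyl gives an at least 1.3-fold higher number from compound 1 to compound 4 (0.11 log units; that floor lies within the scatter), which does not separate the two. The step between the two limits cannot be read.

Going by these compounds, how a plain phenyl, or a carboxylic acid or an amine on the ring, would read at this carbon remains open.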